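From Diisopropylamino to 4-Methylpiperazin-1-yl on a Shared Core

The compounds below may be only part of what the source reports. "The series", "measured", "known", "first", "only" and "open" are said of these compounds alone.

Of the compounds shown here, three sharing one core have been measured in a functional assay on HL-60 cells (Homo sapiens) for antiproliferative activity, read by MTT assay, with a stated time of 48 h; a higher number here means a weaker inhibitor, a lower number a stronger inhibitor. Compound 1 (`CC(=O)OC/C1=C/C[C@](C)(CCC=C(C)C)/C=C/[C@@H](OC(=O)C=C(C)C)[C@](C)(O)/C=C/C1=O`) gives 2950 nM, and compound 2 (`COC/C1=C/C[C@](C)(CCC=C(C)C)/C=C/[C@@H](OC(=O)C=C(C)C)[C@](C)(O)/C=C/C1=O`) gives 3070 nM. Compound 3 (`CC(C)=CCC[C@]1(C)/C=C/[C@@H](OC(=O)C=C(C)C)[C@](C)(O)/C=C/C(=O)/C(CN(C(C)C)C(C)C)=C\C1`) gives 740 nM, the lowest of the three numbers, which makes it the strongest inhibitor measured so far.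

Compound 4 (`CC(C)=CCC[C@]1(C)/C=C/[C@@H](OC(=O)C=C(C)C)[C@](C)(O)/C=C/C(=O)/C(CN2CCN(C)CC2)=C\C1`) keeps the shared core but carries 4-methylpiperazin-1-yl in place of diisopropylamino on a saturated chain carbon bound to a double-bonded ring carbon. For the measured compounds named here, no measured step swaps one amino group for another, so the evidence is indirect. Replacing an oxygen-linked group with diisopropylamino at this place gave modest steps beyond the scatter: a 4.0-fold lower number from compound 1 to compound 3 (0.60 log units; beyond the scatter) and a 4.1-fold lower number from compound 2 to compound 3 (0.62 log units; beyond the scatter). Exchanging one oxygen-linked group for another gave a 1.0-fold higher number from compound 1 to compound 2 (0.02 log units; within the scatter), which lies within the scatter. Since an amino group stays in place here, a step smaller than the two modest ones is expected, leaning toward a higher number and possibly staying within the scatter. The estimated change is a 1.5-fold higher number from compound 3 to compound 4 (0.17 log units; within the scatter). For compound 4, the expected value is 1100 nM, with an estimated range from 450 nM to 2800 nM.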

Compound 4, half-maximal inhibitory concentration: 840 nM
Compound 4: the middle estimate sits 1.3-fold (0.12 log units) above what was measured, and the stated range covers the measured number.
By their numbers in this assay, from the lowest: compounds 3 and 4 (each within the scatter of the next); then compounds 1 and 2 (each within the scatter of the next).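

In this assay, for the compounds shown here, this is the first direct exchange of one amino group for another on a saturated chain carbon bound to a double-bonded ring carbon, and it gives a 1.1-fold higher number from compound 3 to compound 4 (0.06 log units; within the scatter) and so no separation between diisopropylamino and 4-methylpiperazin-1-yl, even though the entering group brings a six-membered non-aromatic ring and a second nitrogen. Compound 4 also stands apart from the oxygen-linked compounds, with a 3.7-fold lower number from compound 2 to compound 4 (0.56 log units; beyond the scatter) against methoxy and a 3.5-fold lower number from compound 1 to compound 4 (0.55 log units; beyond the scatter) against acetoxy. The lower number seen earlier is therefore not tied to diisopropylamino alone: among these four compounds, both amino groups give lower numbers than both oxygen-linked groups, and no compound goes against this.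

On these data alone, it remains open whether a morpholine ring, a primary amine or a carboxylic acid on this same carbon would give a number like those of compound 3 and compound 4, or one like those of compound 1 and compound 2. The data shown offer no explanation for why the two amino groups sit together or why they part from the oxygen-linked groups.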